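The compounds below may be only part of what the source reports. "The series", "measured", "known", "first", "only" and "open" are said of these compounds alone.

Working notes on the series. Compound 3 `CN(/N=N/c1ccc(Br)cc1)C(=O)CCc1ccc(O)cc1` gives 106 h in a physicochemical assay for pharmacokinetics, read by HPLC, in phosphate buffer, at pH 7.4 (on this read-out lower numbers stand for a shorter-lived compound and higher numbers for a longer-lived compound), and stands highest of the two numbers available, with compound 1 `CN(/N=N/c1ccc(C#N)cc1)C(=O)CCc1ccc(O)cc1` nearest at 86.4 h in this assay. For the measured compounds named here, the single measured step, a 1.2-fold higher number from compound 1 to compound 3 (0.09 log units; within the scatter), stays within the scatter. Compound 2 `CCOC(=O)c1ccc(/N=N/N(C)C(=O)NCCSc2ccc(O)cc2)cc1` sits at a limit of this assay, > 240 h, which is a limit and not a number (the limit of > 240 h in this assay, at which 1 of the 3 values shown sits). Compound 4 `CCOC(=O)c1ccc(/N=N/N(C)C(=O)CCc2ccc(O)cc2)cc1` differs from compound 3 by ethoxycarbonyl in place of bromo on an aromatic carbon. Going by the values given here, no measured step covers an exchange of this kind, and the one step known is within the scatter, so no direction can be drawn. For compound 4 the estimate is 130 h in this assay, with a range of 55 h to 300 h, meaning an expected step of a 1.2-fold higher number from compound 3 to compound 4 (0.09 log units; within the scatter).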

Compound 4, half-life: 130 h
Compound 4: the middle estimate sits on the measured number at the digits printed; the measured number falls inside the stated range.
By their numbers in this assay, from the lowest: compounds 1, 3 and 4 (each within the scatter of the next). At a limit, above all of these: compound 2.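

Ethoxycarbonyl in place of bromo gives a 1.2-fold higher number from compound 3 to compound 4 (0.09 log units; within the scatter) in this assay, and ethoxycarbonyl in place of cyano gives a 1.5-fold higher number from compound 1 to compound 4 (0.18 log units; within the scatter) in the same read-out. At this aromatic carbon, para to a large group, bromo, cyano and ethoxycarbonyl therefore all stay within the scatter of one another, and a group of 5 heavy atoms with 2 hydrogen-bond acceptors opens no step beyond it. No measured property available here bears on these steps.

On these data alone, whether an amine or a carboxylic acid on this aromatic carbon would move the half-life beyond the scatter remains open.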